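A few compounds are considered here, and "the series" means these few. Any claim that something is new, unique, unknown or untested is made for them only; others in the source may bear on it.

Measured so far in a functional assay on A549 cells (Homo sapiens) for inhibition, read by MTT assay, with a stated time of 72 h; a higher number here means a weaker inhibitor, a lower number a stronger inhibitor:
compound 1, `COc1cc2c(Oc3ccc(NC(=O)c4nn(-c5ccccc5)cc(C)c4=O)cc3F)ccnc2cc1OCCCC(=O)NO`, gives 1900 nM.
compound 2, `COc1cc2c(Oc3ccc(NC(=O)c4nn(-c5cccc(C)c5)cc(C)c4=O)cc3)ccnc2cc1OCCCCCCC(=O)NO`, gives 280 nM.
compound 3, `COc1cc2c(Oc3ccc(NC(=O)c4nn(-c5ccccc5C)ccc4=O)c(F)c3)ccnc2cc1OCCCCCCC(=O)NO`, reaches only a limit of the assay, > 20000 nM, and not a number.

Compound 1 stands at the higher of the two numbers that were read, the weaker end of what this assay has shown; compound 2 sits well below it, beyond the scatter, while compound 3 gives only the limit (the limit of > 20000 nM in this assay, at which 1 of the 3 values shown sits). Among the compounds with values here, compound 2 and compound 3 differ from compound 1 in several places at once, so no single step between measured compounds can be read from them.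

The new compound is compound 4, `COc1cc2c(Oc3ccc(NC(=O)c4nn(-c5ccccc5F)cc(C)c4=O)cc3F)ccnc2cc1OCCCC(=O)NO`. It differs from compound 1 in one place: fluoro in place of hydrogen on an aromatic carbon. The group entering is small, a single heavy atom with no ring and no donor or acceptor, so in this assay only a modest step is expected from compound 1, within or near the scatter, with no clear direction; the step expected from compound 1 to compound 4 is a 1.3-fold lower number from compound 1 to compound 4 (0.10 log units; within the scatter). Compound 4 is accordingly estimated at 1500 nM, between 500 nM and 6000 nM.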

Compound 4, half-maximal inhibitory concentration: 1370 nM
Compound 4: middle estimate off by 1.1-fold (0.04 log units), on the high side; low and high end bracket the measured number.
By their numbers in this assay, from the lowest: compound 2; then compounds 4 and 1 (each within the scatter of the next). At a limit, above all of these: compound 3.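

In this assay the change from phenyl to 2-fluorophenyl gives a 1.4-fold lower number from compound 1 to compound 4 (0.14 log units; within the scatter), so fluoro in place of hydrogen on this aromatic carbon, ortho to a large group, leaves the number within the scatter and the position accepts this single heavy atom without a measurable loss. Within the data shown here, this is the first step that can be read at one place, since compound 2 and compound 3 each differ from the others in several places and say nothing about this position on its own. Nothing at hand offers a reason for the size of this step, or shows whether the fluoro has any effect of its own here.

Going by these compounds, whether this position stays as undemanding with a larger or charged group, such as chloro, trifluoromethyl or an amine ortho to a large group, remains open, as one small atom says little about the room for anything bigger. Also open, on these data alone, is which of the several differences sets compound 2 apart from compound 1 and compound 4, and the steps to compound 2 and compound 3 cannot be read.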